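Chain shape at the amide alkene of a thienopyrimidine series

This account rests on a few compounds, and the source may have more. Where it says the series, first, only, none or still open, it means among the compounds named here.

Compound 1 `C=CC(=O)Nc1cccc(Oc2nc(Nc3cccc(C#N)c3)nc3ccsc23)c1` gives 6390 nM in a functional assay on HeLa cells (Homo sapiens) for inhibition, read by MTT assay, with a stated time of 72 h; on this read-out higher numbers stand for weaker inhibition and lower numbers for stronger inhibition.
Compound 2 `CC(C)=CC(=O)Nc1cccc(Oc2nc(Nc3cccc(C#N)c3)nc3ccsc23)c1` gives 19800 nM in this assay.
Compound 3 `CC(C)/C=C/C(=O)Nc1cccc(Oc2nc(Nc3cccc(C#N)c3)nc3ccsc23)c1` gives 36500 nM in this assay.

Of the three measured compounds, compound 3 shows the highest number. Its nearest neighbour is compound 2, and the step of a 1.8-fold higher number from compound 2 to compound 3 (0.27 log units; within the scatter) stays within the scatter; its furthest is compound 1, and the step of a 5.7-fold higher number from compound 1 to compound 3 (0.76 log units; beyond the scatter) lies beyond the scatter, as does a 3.1-fold higher number from compound 1 to compound 2 (0.49 log units; beyond the scatter).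

Compound 4 `CCC/C=C/C(=O)Nc1cccc(Oc2nc(Nc3cccc(C#N)c3)nc3ccsc23)c1` differs from compound 3 only in the arrangement of the same atoms: propyl in place of isopropyl on a double-bonded chain carbon bound to a double-bonded chain carbon. Within the data shown here, no measured step compares a branched with a straight chain at that carbon. Among the measured compounds shown here, the only steps that bear on it indirectly are a 3.1-fold higher number from compound 1 to compound 2 (0.49 log units; beyond the scatter) and a 5.7-fold higher number from compound 1 to compound 3 (0.76 log units; beyond the scatter), which show that adding carbon to the alkene raised the number, and a 1.8-fold higher number from compound 2 to compound 3 (0.27 log units; within the scatter), which shows that shifting where that carbon sits changed little. For compound 4 the step of a 1.0-fold lower number from compound 3 to compound 4 (0.02 log units; within the scatter) is therefore expected to fall within the scatter. Compound 4 is estimated at 35000 nM, within a range from 14000 nM to 90000 nM.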

Compound 4, half-maximal inhibitory concentration: 42100 nM
Beside the measured number, compound 4's estimate is 1.2-fold (0.08 log units) below it, and the stated range covers the measured number.
By their numbers in this assay, from the lowest: compound 1; then compounds 2, 3 and 4 (each within the scatter of the next, the first and the last beyond it).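

In this assay, among these compounds, the step of a 1.2-fold higher number from compound 3 to compound 4 (0.06 log units; within the scatter) is the first direct comparison of a branched and a straight chain at this carbon, and it does not tell propyl from isopropyl. Measured from the other alkenes on the carbonyl carbon, a 2.1-fold higher number from compound 2 to compound 4 (0.33 log units; beyond the scatter) only just passes the scatter, whereas the step from compound 2 to compound 3 stayed within it, so this slight difference between the two chains should not be read as a real separation. The step of a 6.6-fold higher number from compound 1 to compound 4 (0.82 log units; beyond the scatter) is the largest in the set and extends the earlier finding that the vinyl amide, compound 1, gives the lowest number.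

On these data alone, whether a longer chain at this carbon, or an amine or a carboxylic acid in place of propyl, would give a number apart from those of compound 3 and compound 4 remains open. No evidence accompanies these numbers to account for them.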